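This account rests on a few compounds, and the source may have more. Where it says the series, first, only, none or still open, it means among the compounds named here.

Measured in a functional assay on HepG2 cells (Homo sapiens) for inhibition, read by sulforhodamine B assay, with a stated time of 74 h; on this read-out higher numbers stand for weaker inhibition and lower numbers for stronger inhibition:
- compound 1 `Cc1ccc(S(=O)(=O)N2C(=O)COC23C=CC(=O)C=C3)cc1`: > 10000 nM (a limit)
- compound 2 `Cc1ccc(S(=O)(=O)N2C(=O)C(C)OC23C=CC(=O)C=C3)cc1`: 540 nM
- compound 3 `O=C1C=CC2(C=C1)OCC(=O)N2S(=O)(=O)c1ccc([N+](=O)[O-])cc1`: > 10000 nM (a limit)

Compound 1 has no number to start from. Its entry of > 10000 nM is a limit. The same ceiling recurs in this small set, as the limit of > 10000 nM in this assay, at which 2 of the 3 values shown sit.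

The next compound is compound 4 `O=C1C=CC2(C=C1)OCC(=O)N2S(=O)(=O)c1ccc(OC(F)(F)F)cc1`, with trifluoromethoxy in place of methyl on an aromatic carbon, para to a large group: trifluoromethoxy in place of methyl on an aromatic carbon.

The nearest measured change at that place is a step that the two limits leave unreadable from compound 1 to compound 3, with nitro in place of methyl on an aromatic carbon. It gives no size and no direction, only the observation that replacing the methyl there did not yield a number. Among the measured compounds shown here, the one readable change is an at least 18-fold lower number from compound 1 to compound 2 (1.26 log units; beyond the scatter), with methyl in place of hydrogen on a saturated ring carbon. That change lies elsewhere in the structure and the aromatic substituent in compound 2 remains methyl, so it is not carried over to compound 4.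

No clear step is therefore expected in this assay, and a reading at the limit is the likeliest outcome. The expected change is a step that the limit leaves unreadable from compound 1 to compound 4, an estimate with little weight behind it. Compound 4 is estimated at 12000 nM, with an expected range of 3000 nM to 40000 nM.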

Compound 4, half-maximal inhibitory concentration: > 10000 nM
Compound 4: a limit, no number; the forecaster's own chance of this, stated with the estimate: 65%; the middle value lies beyond the limit too.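

In this assay compound 4 gives > 10000 nM, which is a limit and not a number. Among the compounds shown here, its steps from compound 1 and compound 3 cannot be read, so it adds no new step. The compounds shown leave open what any change of the aromatic substituent does to the number, as the same ceiling recurs: the limit of > 10000 nM in this assay, at which 3 of the 4 values shown sit.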